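A chloro step on compound 1

The source may hold more compounds than are shown below. What is called first, only, known or untested is meant among the compounds shown, and "the series" means these compounds.

Measured in a functional assay on K562 cells (Homo sapiens) for antiproliferative activity, read by MTT assay, with a stated time of 48 h (a lower number here means a stronger inhibitor, a higher number a weaker inhibitor), are three compounds
- compound 1 `CCN(CC)CCCn1c(N)c(-c2nc3ccccc3[nH]2)c2nc(C#N)c(C#N)nc21` gives 1800 nM
- compound 2 `N#Cc1nc2c(-c3nc4ccccc4[nH]3)c(N)n(CCCO)c2nc1C#N` gives > 50000 nM
- compound 3 `N#Cc1nc2c(-c3nc4ccccc4[nH]3)c(N)n(CCCN3CCCCC3)c2nc1C#N` gives 3460 nM

Compound 2 shows > 50000 nM as a limit of the assay and not as a number.

Compound 1 and compound 3 are the two with numbers, and a 1.9-fold higher number from compound 1 to compound 3 (0.28 log units; within the scatter) leaves them level. The gap to the limit is far wider, with an at least 27-fold higher number from compound 1 to compound 2 (1.44 log units; beyond the scatter) and an at least 14-fold lower number from compound 2 to compound 3 (1.15 log units; beyond the scatter) as the two steps that show it.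

Compound 4 `CCN(CC)CCCn1c(N)c(-c2nc3cc(Cl)ccc3[nH]2)c2nc(C#N)c(C#N)nc21` keeps the shared core and differs from compound 1 in one place, chloro in place of hydrogen on an aromatic carbon with chloro in place of hydrogen on an aromatic carbon, turning 1H-benzimidazol-2-yl into 5-chloro-1H-benzimidazol-2-yl. All three measured steps change only the chain end, so none of them covers this change. Compound 4 keeps the diethylamino chain of compound 1, which gives 1800 nM in this assay and so no step beyond the scatter is expected. The expected step is a 1.3-fold lower number from compound 1 to compound 4 (0.11 log units; within the scatter) as an estimate only. For compound 4 the estimated value is 1400 nM with an expected range from 400 nM to 5000 nM until the measurement is known.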

Compound 4, half-maximal inhibitory concentration: 4830 nM
Compound 4: middle estimate off by 3.5-fold (0.54 log units), on the low side, and the stated range covers the measured number.
By their numbers in this assay, from the lowest: compounds 1, 3 and 4 (each within the scatter of the next, the first and the last beyond it). At a limit, above all of these: compound 2.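

Within the data shown here, the earlier steps all change the chain end, whereas this step is the first to change the 1H-benzimidazol-2-yl group. In this assay the change to 5-chloro-1H-benzimidazol-2-yl, with the diethylamino chain kept, gives a 2.7-fold higher number from compound 1 to compound 4 (0.43 log units; beyond the scatter) and so shows that this aromatic carbon is not indifferent to substitution: a single chlorine in place of hydrogen modestly weakens the antiproliferative effect. Nothing in the data shown accounts for this step.

On these data alone, it remains open whether fluoro, methyl or methoxy at this carbon would move the number as chloro does, or whether chloro would act differently on another carbon of the same ring. Also open, as far as these compounds go, is whether chloro would give a similar step on the piperidin-1-yl chain of compound 3.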